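Swapping methyl for chloro on the benzyl arm

The source may report more compounds than this note shows. Statements on the series, on what has been measured and on what is new or still open speak of the compounds shown alone.

Compound 1 `CCNc1ncc(C(=O)O)c2nc(-c3ccco3)nn12`: 11900 nM
Compound 2 `CCCCC(CC)CNc1ncc(C(=O)O)c2nc(-c3ccco3)nn12`: 1780 nM
Compound 3 `Cc1ccc(CNc2ncc(C(=O)O)c3nc(-c4ccco4)nn23)cc1`: 2730 nM

Of the compounds shown here, three sharing one core have been tested in an assay on CHO cells for displacement of a labelled ligand from adenosine receptor A1 (Homo sapiens); a higher number here means a weaker inhibitor, a lower number a stronger inhibitor. Compound 3 stands second highest of the three numbers: it sits close to compound 2, with a 1.5-fold higher number from compound 2 to compound 3 (0.19 log units; within the scatter), and well apart from compound 1, with a 4.4-fold lower number from compound 1 to compound 3 (0.64 log units; beyond the scatter). Both measured steps beyond the scatter, a 6.7-fold lower number from compound 1 to compound 2 (0.83 log units; beyond the scatter) and a 4.4-fold lower number from compound 1 to compound 3 (0.64 log units; beyond the scatter), concern the size of the group attached to the ring nitrogen, not the substituent on the benzyl ring itself.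

Compound 4 `O=C(O)c1cnc(NCc2ccc(Cl)cc2)n2nc(-c3ccco3)nc12` is not yet measured. It differs from compound 3 in one place: chloro in place of methyl on an aromatic carbon. Within the data shown here, no measured step covers such a swap on the aromatic ring, so the data give no direction for this change. The step from compound 3 to compound 4 in this assay is therefore expected to be small, a 1.1-fold lower number from compound 3 to compound 4 (0.04 log units; within the scatter), within the usual scatter. Compound 4 is estimated at 2500 nM, with a likely range from 1000 nM to 6500 nM.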

Compound 4, inhibition constant: > 100000 nM
Compound 4 ended at the assay's limit; the forecaster's own chance of this, stated with the estimate: 2%; at least 40-fold (1.60 log units) between middle value and limit.
By their numbers in this assay, from the lowest: compounds 2 and 3 (each within the scatter of the next); then compound 1. At a limit, above all of these: compound 4.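

In this assay compound 4 ends at a limit, not at a number: the limit of > 100000 nM in this assay, at which 1 of the 4 values shown sits. The earlier compounds shown here varied only the arm on the ring nitrogen, and there the numbers shifted modestly, whereas one atom changed on the benzyl ring gives an at least 36-fold higher number from compound 3 to compound 4 (1.56 log units; beyond the scatter), so this para carbon matters far more than those compounds suggested. The 4-chlorobenzyl arm also falls behind both other arms, with an at least 56-fold higher number from compound 2 to compound 4 (1.74 log units; beyond the scatter) and an at least 8.4-fold higher number from compound 1 to compound 4 (0.92 log units; beyond the scatter), which makes compound 4 the weakest of the four, even behind the short arm of compound 1.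

The compounds shown do not say why chloro differs so sharply from methyl. Fluoro, methoxy or a plain hydrogen at this carbon would show whether the loss belongs to chloro alone or to a wider range of groups.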